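The source may hold more compounds than are shown below. What is called first, only, known or untested is meant among the compounds shown, and "the series" means these compounds.

Compound 1 `COc1ccc(-c2cc(/C=C/C(=O)c3ccc(N)cc3)[nH]n2)cc1` gives 2320 nM in a functional assay on MOLT-4 cells (Homo sapiens) for inhibition, read by sulforhodamine B assay, with a stated time of 48 h; a lower number here means a stronger inhibitor of growth, a higher number a weaker inhibitor of growth.
Compound 2 `COc1cc(-c2cc(/C=C/C(=O)c3ccc(N)cc3)[nH]n2)cc(OC)c1OC` gives 1910 nM in this assay.
Compound 3 `COc1ccc(C(=O)/C=C/c2cc(-c3cc(OC)c(OC)c(OC)c3)n[nH]2)cc1OC` gives 2110 nM in this assay.

Compound 2 holds the lowest of the three numbers, yet all three sit close together: the step of a 1.1-fold higher number from compound 2 to compound 3 (0.04 log units; within the scatter) stays within the scatter, and compound 1 and compound 2 give numbers that are likewise close. Compound 4 `COc1ccc(-c2cc(/C=C/C(=O)c3ccc(N)cc3)[nH]n2)cc1OC` differs from compound 2 by hydrogen in place of methoxy on an aromatic carbon. Among the compounds with values here, no measured step alters this ring in one place; the only single-place step, a 1.1-fold higher number from compound 2 to compound 3 (0.04 log units; within the scatter), changes the ring on the carbonyl carbon and brought no shift beyond the scatter. Compound 4 is therefore expected to give a number close to that of compound 2, with no step beyond the scatter. The estimate for compound 4 is 2100 nM, between 1100 nM and 4000 nM. This estimate means an expected step of a 1.1-fold higher number from compound 2 to compound 4 (0.04 log units; within the scatter).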

Compound 4, concentration for 50% growth inhibition: 3110 nM
For compound 4 the middle estimate is 1.5-fold (0.17 log units) below the measured one; the range from low to high includes it.
By their numbers in this assay, from the lowest: compounds 2, 3, 1 and 4 (each within the scatter of the next).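

Within the data shown here, the compounds now give single-place steps on this ring, which the earlier compounds did not: hydrogen in place of methoxy on an aromatic carbon (a 1.6-fold higher number from compound 2 to compound 4 (0.21 log units; within the scatter)) and methoxy in place of hydrogen on an aromatic carbon (a 1.3-fold higher number from compound 1 to compound 4 (0.13 log units; within the scatter)). Both steps lie within the scatter, so in this assay neither change separates the compounds involved. No further evidence bears on these steps. The compounds shown leave open whether a hydroxyl group or an amine on this aromatic carbon would give a step beyond the scatter.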